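Shortening the ether chain of compound 2: an estimate

The source may hold more compounds than are shown below. What is called first, only, known or untested is meant among the compounds shown, and "the series" means these compounds.

Measured compounds:
compound 1, `O=C(O)COc1ccc(-c2coc3cc(OCC(=O)O)ccc3c2=O)cc1`, >> 9000 nM (a limit)
compound 2, `NCCCCCCOc1ccc2c(=O)c(-c3ccc(O)cc3)coc2c1`, 100 nM
compound 3, `O=C(O)CCCCCCCCCCCCCCCOc1ccc2c(=O)c(-c3ccc(O)cc3)coc2c1`, > 9000 nM (a limit)

Among the compounds with values here, in an assay (Cricetulus griseus) for inhibition of aldehyde dehydrogenase, mitochondrial (Homo sapiens) (a higher number here means a weaker inhibitor, a lower number a stronger inhibitor), compound 2 gives 100 nM, the only number among the three results. Compound 1 sits at a limit, >> 9000 nM. Compound 3 likewise sits at a limit, > 9000 nM. Within the data shown here, the one step between compounds differing in a single place is an at least 90-fold higher number from compound 2 to compound 3 (1.95 log units; beyond the scatter), in which the terminal amine of the chain was exchanged for a long carboxylic acid chain; its size is bounded only by the limit of > 9000 nM in this assay, at which 1 of the 3 values shown sits.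

Compound 4, `CCOc1ccc2c(=O)c(-c3ccc(O)cc3)coc2c1`, is related to compound 2 by hydrogen in place of 4-aminobutyl on a saturated chain carbon, two bonds along the chain from an oxygen on an aromatic ring. This removes the amine but, unlike the step to compound 3, introduces no acid and no extra chain, so the measured step bears on it only partly. Among the measured compounds shown here, the terminal amine is the one feature present in compound 2 and absent in both limit compounds, so its loss is expected to weaken binding, though less than in the step to compound 3. The expected step is a 5.0-fold higher number from compound 2 to compound 4 (0.70 log units; beyond the scatter). Compound 4 is therefore estimated at 500 nM, within 100 nM to 3000 nM.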

Compound 4, half-maximal inhibitory concentration: 80 nM
For compound 4 the middle estimate is 6.3-fold (0.80 log units) above the measured one, outside the stated range (below it).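

In this assay, the exchange at this position reads a 1.3-fold lower number from compound 2 to compound 4 (0.10 log units; within the scatter): hydrogen in place of 4-aminobutyl, or, cut further out, 6-aminohexyl to ethyl. Within the data shown here, the terminal amine and the chain carrying it are therefore not needed for a value of this order, which the earlier compounds could not show, as the only measured exchange of the amine, an at least 90-fold higher number from compound 2 to compound 3 (1.95 log units; beyond the scatter), also brought in the 9-carboxynonyl group. That large step can no longer be read as the loss of the amine alone, and nothing shown here gives a cause for either step.

The compounds shown leave open what a carboxylic acid does on a chain as short as the ethyl of compound 4 or as long as the hexyl chain of compound 2, and so whether the acid, the length of the chain or both go with the weak reading of compound 3. They also leave open whether a plain hexyl chain, with neither an amine nor a carboxylic acid at its end, would read like the two short-to-medium chains measured.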